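The source may hold more compounds than are shown below. What is called first, only, known or untested is meant among the compounds shown, and "the series" means these compounds.

Compound 1 `CNC(=O)c1ccc(Oc2cccc(NC(=S)Nc3ccc(C)c(C)c3)c2)nc1` gives 67400 nM in a functional assay on PC-3 cells (Homo sapiens) for antiproliferative activity, read by MTT assay; on this read-out lower numbers stand for stronger inhibition and higher numbers for weaker inhibition. Compound 2 `CNC(=O)c1ccc(Oc2cccc(NC(=S)Nc3ccc(F)c(C(F)(F)F)c3)c2)nc1` gives 7950 nM. Compound 3 `CNC(=O)c1ccc(Oc2cccc(NC(=S)Nc3cccc(C(F)(F)F)c3)c2)nc1` gives 15400 nM.

Compound 3 stands second highest of the three numbers. Its nearest neighbour is compound 2, where the change is a 1.9-fold higher number from compound 2 to compound 3 (0.29 log units; within the scatter); its furthest is compound 1, where the change is a 4.4-fold lower number from compound 1 to compound 3 (0.64 log units; beyond the scatter). Compound 4 `CNC(=O)c1ccc(Oc2cccc(NC(=S)Nc3ccc(F)c(Cl)c3)c2)nc1` differs from compound 3 by 3-chloro-4-fluorophenyl in place of 3-(trifluoromethyl)phenyl on an amide-type nitrogen. Both measured steps bear on this: one shows that exchanging the aryl group on that nitrogen moved the number modestly, the other that adding or removing a fluoro stayed within the scatter. A step within the scatter, leaning slightly lower, is therefore expected, a 1.4-fold lower number from compound 3 to compound 4 (0.15 log units; within the scatter). Compound 4 is estimated at 11000 nM, between 4000 nM and 30000 nM.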

Compound 4, half-maximal inhibitory concentration: 18400 nM
Compound 4: middle estimate off by 1.7-fold (0.22 log units), on the low side; low and high end bracket the measured number.
By their numbers in this assay, from the lowest: compounds 2, 3 and 4 (each within the scatter of the next, the first and the last beyond it); then compound 1.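

On this nitrogen, 3-chloro-4-fluorophenyl and 3-(trifluoromethyl)phenyl cannot be told apart, with a 1.2-fold higher number from compound 3 to compound 4 (0.08 log units; within the scatter) as the whole difference. Yet when the fluoro stays in place, chloro in place of trifluoromethyl does show, giving a 2.3-fold higher number from compound 2 to compound 4 (0.36 log units; beyond the scatter) as a modest step, while 3-chloro-4-fluorophenyl keeps a modest edge over 3,4-dimethylphenyl, with a 3.7-fold lower number from compound 1 to compound 4 (0.56 log units; beyond the scatter) as the gain. Nothing measured here explains these steps. Still open, as far as these compounds go, is how an amine or a carboxylic acid on this aryl ring, or a longer chain in its place, would fare.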